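An Ethoxy Group Added to the Strongest of Three

The source may report more compounds than this note shows. Statements on the series, on what has been measured and on what is new or still open speak of the compounds shown alone.

Of the compounds shown here, three built on one shared core have been measured in a functional assay on CHO cells for agonist activity at Free fatty acid receptor 1 (Homo sapiens), read by FLIPR and calcium flux, with a stated time of 90 s, tested at 100 nM; on this read-out higher numbers stand for a stronger effect at the one concentration tested and lower numbers for a weaker effect. Compound 1 `O=C(O)CC1COc2cc(OCc3cccc(N4CCCCC4)c3)ccc21` gives 34.7%. Compound 2 `Cc1ccc(C)n1-c1cccc(COc2ccc3c(c2)OCC3CC(=O)O)c1` gives 59.9%, the highest of the three numbers. The change behind that rise is a number 25.2 percentage points higher from compound 1 to compound 2 (beyond the scatter). Compound 3 `COCc1cc(C)n(-c2cccc(COc3ccc4c(c3)OCC4CC(=O)O)c2)c1C` gives 31.7%; the drop from the top compound is a number 28.2 percentage points lower from compound 2 to compound 3 (beyond the scatter), whereas a number 3 percentage points lower from compound 1 to compound 3 (within the scatter).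

Compound 4 `CCOc1ccc(COc2ccc3c(c2)OCC3CC(=O)O)cc1-n1c(C)ccc1C` has not yet been measured. It differs from compound 2 in one place: ethoxy in place of hydrogen on an aromatic carbon. Among the compounds with values here, none of the measured steps involves an ethoxy group or touches this place on the six-membered aromatic ring of carbon only. Within the data shown here, the only measured step that starts from the top compound and adds a group is a number 28.2 percentage points lower from compound 2 to compound 3 (beyond the scatter), but that methoxymethyl sits on the pyrrolyl group, so it offers no direct guide here. Among the measured compounds shown here, with no close precedent, compound 4 is expected to stay in the neighbourhood of its parent, a number 7.9 percentage points lower from compound 2 to compound 4 (within the scatter), and the uncertainty is wide. Compound 4 is estimated at 52%, between 25% and 78%.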

Compound 4, a percentage reported as activity, at one concentration (the size of the read-out at that concentration, not a potency): 54.6%
Compound 4: middle estimate off by 2.6 percentage points, on the low side; the measured number falls inside the stated range.
By their numbers in this assay, from the lowest: compounds 3 and 1 (each within the scatter of the next); then compounds 4 and 2 (each within the scatter of the next).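

Within the data shown here, on the six-membered aromatic ring of carbon only, ortho to the 2,5-dimethyl-1H-pyrrol-1-yl group and para to a large group, ethoxy in place of hydrogen leads to a number 5.3 percentage points lower from compound 2 to compound 4 (within the scatter) in this assay, so this place, untouched by the earlier steps, takes the group with no change that can be told from scatter. The only earlier addition, methoxymethyl on the pyrrolyl group, led to a number 28.2 percentage points lower from compound 2 to compound 3 (beyond the scatter), which shows that not every added group reads the same on this scaffold. Nothing measured here explains that contrast.

On these data alone, whether it follows from the group or from the place stays open, since ethoxy and methoxymethyl differ in both. Also open, as far as these compounds go, is how methoxy, a longer propoxy chain or an amine would read at this same place.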